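Three Limits, One Unmeasured Dichlorophenyl Analogue

The compounds below may be only part of what the source reports. "The series", "measured", "known", "first", "only" and "open" are said of these compounds alone.

Compound 1, `N#CC1=C(N)Oc2c(N)cc3nc4ccccc4nc3c2C12C(=O)N(Cc1cnnn1-c1ccc(Cl)cc1)c1ccccc12`, in an ADME assay on HUVEC cells (Homo sapiens) for antiproliferative activity, read by MTT assay, with a stated time of 48 h; on this read-out higher numbers stand for weaker inhibition and lower numbers for stronger inhibition: > 50000 nM, a limit of the assay.
Compound 2, `COc1ccc(-n2nncc2CN2C(=O)C3(C(C#N)=C(N)Oc4c(N)cc5nc6ccccc6nc5c43)c3ccccc32)cc1`, in this assay: > 50000 nM, again a limit.
Compound 3, `CCOc1ccccc1-n1nncc1CN1C(=O)C2(C(C#N)=C(N)Oc3c(N)cc4nc5ccccc5nc4c32)c2ccccc21`, in this assay: > 50000 nM, also a limit.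

All three compounds share one core and differ only in the aryl group carried on the triazole nitrogen. For compound 3 the value is only a limit, so its standing among the three cannot be ranked. The steps between the measured compounds give no readable size: a step that the two limits leave unreadable from compound 1 to compound 2, a step that the two limits leave unreadable from compound 1 to compound 3 and a step that the two limits leave unreadable from compound 2 to compound 3. Among the compounds with values here, the one piece of evidence is the limit of > 50000 nM in this assay, at which 3 of the 3 values shown sit.

Compound 4, `N#CC1=C(N)Oc2c(N)cc3nc4ccccc4nc3c2C12C(=O)N(Cc1cnnn1-c1ccc(Cl)cc1Cl)c1ccccc12`, is the next analogue. The change from compound 3 is 2,4-dichlorophenyl in place of 2-ethoxyphenyl on an aromatic nitrogen. Within the data shown here, none of the measured steps gives a readable size, so no direction for this assay can be drawn from them; the only ground is that every aryl variant so far sits at the limit. The expected step that the limit leaves unreadable from compound 3 to compound 4 is therefore none beyond the scatter, and compound 4 is estimated to remain at or near the limit, with an estimate of 70000 nM and a range from 20000 nM to 250000 nM.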

Compound 4, half-maximal inhibitory concentration: > 50000 nM
Compound 4: only a limit was reported (the forecaster's own chance of this, stated with the estimate: 85%); the middle value is on the limit's open side.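

Compound 4 gives only a limit, as do compound 1, compound 2 and compound 3, so no step among these four compounds can be read in this assay at all, and what remains is this: the limit of > 50000 nM in this assay, at which 4 of the 4 values shown sit. The compounds shown leave open whether any aryl group on the shared core gives a value that is a real number rather than a limit.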